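Notes on a cyclohexyl-for-isopropyl exchange in cell inhibition

The compounds below may be only part of what the source reports. "The series", "measured", "known", "first", "only" and "open" are said of these compounds alone.

Compound 1 `COc1ccc(C(=O)/C(=C/c2ccc(Cl)cc2Cl)CC(C)C)cc1` is the reference of the dichlorinated pair; in a functional assay on A549 cells (Homo sapiens) for inhibition, read by XTT assay, with a stated time of 48 h (a higher number here means a weaker inhibitor, a lower number a stronger inhibitor), compound 1 gives 80300 nM. Compound 3 `COc1ccc(C(=O)/C(=C/c2ccc(Cl)cc2Cl)CC2CCCCC2)cc1` shares that core, with cyclohexyl in place of isopropyl on a saturated chain carbon bound to a double-bonded chain carbon. For compound 3 the reading in this assay is a limit of the assay, > 100000 nM. The measured step of an at least 1.2-fold higher number from compound 1 to compound 3 (0.09 log units; that floor lies within the scatter) is thus only a floor, and the evidence bearing on it is the limit of > 100000 nM in this assay, at which 2 of the 3 values shown sit.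

Compound 2 `COc1ccc(C(=O)/C(=C/c2ccc(C(F)(F)F)cc2)CC(C)C)cc1` carries a trifluoromethyl ring instead; the difference between the two cores is not broken down here. For compound 2 the reading in this assay is also a limit of the assay, > 100000 nM. Compound 4 `COc1ccc(C(=O)/C(=C/c2ccc(C(F)(F)F)cc2)CC2CCCCC2)cc1` is the unmeasured partner of compound 2, with cyclohexyl in place of isopropyl on a saturated chain carbon bound to a double-bonded chain carbon, the same change at the same place as between compound 1 and compound 3.

Compound 4 is expected to show a step that the limit leaves unreadable from compound 2 to compound 4 in this assay, set beside the earlier floor. That expectation rests on compound 2 already sitting at the limit > 100000 nM. It rests further on the same change giving an at least 1.2-fold higher number from compound 1 to compound 3 (0.09 log units; that floor lies within the scatter). For compound 4 the estimate in this assay is 250000 nM, between 100000 nM and 1000000 nM, and most likely reported only as a limit.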

Compound 4, half-maximal inhibitory concentration: > 100000 nM
Compound 4 was reported as a limit; the forecaster's own chance of this, stated with the estimate: 90%; the middle value lies beyond the limit too.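

In this assay compound 4 reads > 100000 nM, a limit of the assay. Compound 2 also stands at a limit, so no step can be read from compound 2 to compound 4. The compounds shown leave open how far cyclohexyl in place of isopropyl shifts the reading in either pair, with the evidence stopping at one point: the limit of > 100000 nM in this assay, at which 3 of the 4 values shown sit.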